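The compounds below may be only part of what the source reports. "The series", "measured", "known", "first", "only" and "open" are said of these compounds alone.

In a functional assay on QGY-7703 cells (Homo sapiens) for cytotoxicity, read by MTT assay, with a stated time of 24 h (a lower number here means a stronger inhibitor, a higher number a weaker inhibitor), compound 1 `CC(=O)Nc1ccc(S(=O)(=O)N2C/C(=C\c3cccnc3)C(=O)/C(=C/c3ccccc3C(F)(F)F)C2)cc1` gives 5380 nM, compound 2 `O=C1/C(=C/c2ccncc2)CN(S(=O)(=O)c2ccccc2)C/C1=C\c1ccccc1C(F)(F)F` gives 6210 nM and compound 3 `O=C1/C(=C/c2ccncc2)CN(S(=O)(=O)c2ccc(F)cc2)C/C1=C\c1ccccc1C(F)(F)F` gives 7700 nM. Compound 3 thus stands within the scatter of both other compounds. Compound 4 `CC(=O)Nc1ccc(S(=O)(=O)N2C/C(=C\c3ccncc3)C(=O)/C(=C/c3ccccc3C(F)(F)F)C2)cc1` has acetamido in place of the fluoro of compound 3, on an aromatic carbon, para to a large group: acetamido in place of fluoro on an aromatic carbon. For the measured compounds named here, the one measured step at this place, a 1.2-fold higher number from compound 2 to compound 3 (0.09 log units; within the scatter), stays within the scatter. Compound 1 also carries 4-acetamidophenyl and, at 5380 nM, shows no separation from compound 3. No step beyond the scatter is therefore expected in this assay. The expected step is a 1.4-fold lower number from compound 3 to compound 4 (0.15 log units; within the scatter). Compound 4 is estimated at 5500 nM, with an expected range from 2900 nM to 10500 nM.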

Compound 4, half-maximal inhibitory concentration: 5560 nM
Estimate against measurement, compound 4: 1.0-fold (0.00 log units) below; the range from low to high includes it.
By their numbers in this assay, from the lowest: compounds 1, 4, 2 and 3 (each within the scatter of the next).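

In this assay, acetamido at this position, on an aromatic carbon, shows no separation from fluoro (a 1.4-fold lower number from compound 3 to compound 4 (0.14 log units; within the scatter)) or from hydrogen (a 1.1-fold lower number from compound 2 to compound 4 (0.05 log units; within the scatter)), so this larger group, with its hydrogen-bond donor and acceptor, is tolerated here within the scatter. With 4-acetamidophenyl in place, pyridin-4-yl in place of pyridin-3-yl also stays within the scatter (a 1.0-fold higher number from compound 1 to compound 4 (0.01 log units; within the scatter)). Nothing measured here accounts for this flat response.

On these data alone, whether an amine or a carboxylic acid at this position would also stay within the scatter remains open. So does whether a methoxy group would.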